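This account rests on a few compounds, and the source may have more. Where it says the series, first, only, none or still open, it means among the compounds named here.

Measured in an ADME assay on a cell-free system (plasma, Homo sapiens) for protein binding, with Plasma (Rattus norvegicus) as the target, with a stated time of 1 h; a higher number here means a larger unbound share of the compound, a lower number a smaller unbound share
- compound 1 `CNC(=O)c1cc(F)ccc1CNC(=O)c1nc(C(C)(C)C)n(C)c(=O)c1O` gives 0.07
- compound 2 `Cn1c(C(C)(C)C)nc(C(=O)NCc2ccc(F)cc2C(N)=O)c(O)c1=O` gives 0.06

Compound 2 stands within the scatter of compound 1, so the pair offers no separation on these numbers. Compound 3 `CCNC(=O)c1cc(F)ccc1CNC(=O)c1nc(C(C)(C)C)n(C)c(=O)c1O` follows from compound 2 by ethyl in place of hydrogen on an amide-type nitrogen, which is ethyl in place of hydrogen on an amide-type nitrogen. Among the measured compounds shown here, no ethyl example has been measured yet. With only a 1.2-fold lower number from compound 1 to compound 2 (0.07 log units; within the scatter) as a measured step on this kind of nitrogen, no step beyond the scatter is expected in this assay, in either direction. The estimated step is no change at the digits printed from compound 2 to compound 3 (within the scatter). For compound 3 the expected value is 0.06, with an expected range of 0.03 to 0.1.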

Compound 3, unbound fraction: 0.03
Estimate against measurement, compound 3: 2.0-fold (0.30 log units) above; the range from low to high includes it.
By their numbers in this assay, from the lowest: compounds 3, 2 and 1 (each within the scatter of the next, the first and the last beyond it).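

In this assay the amide-type nitrogen now shows its first step beyond the scatter, a modest one, with a 2.3-fold lower number from compound 1 to compound 3 (0.37 log units; beyond the scatter) as the methyl extends to ethyl. Ethyl in place of hydrogen gives a 2.0-fold lower number from compound 2 to compound 3 (0.30 log units; within the scatter) and so remains unresolved, which means only the methyl and ethyl pair is separated on this nitrogen. Hydrogen, methyl and ethyl therefore do not yet form a graded series.

As far as these compounds go, whether a longer chain such as propyl, or a chain carrying an amine or a carboxylic acid, would shift the unbound fraction further on this nitrogen stays open. Nothing available bears on the cause of the step.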